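Chloro to Bromo on a Caffeate Ester Scaffold

The compounds below may be only part of what the source reports. "The series", "measured", "known", "first", "only" and "open" are said of these compounds alone.

Measured compounds:
compound 1, `O=C(/C=C/c1cc(O)c(O)c([N+](=O)[O-])c1)OCCc1ccccc1`, "not determined" (no result reported) in a functional assay on SGC-7901 cells (Homo sapiens) for inhibition, read by MTT assay; on this read-out lower numbers stand for stronger inhibition and higher numbers for weaker inhibition
compound 2, `O=C(/C=C/c1cc(O)c(O)c(Cl)c1)OCCc1ccccc1`, 8180 nM

Compound 2 carries the only number shown; compound 1 was tested in this assay but no single result was reported for it, its entry reading "not determined" (no result reported). In this assay compound 2 gives 8180 nM. Compound 3, `O=C(/C=C/c1cc(O)c(O)c(Br)c1)OCCc1ccccc1`, has not yet been measured. It differs from compound 2 in a single place: bromo in place of chloro on an aromatic carbon. Among the measured compounds shown here, no step between two measured compounds is available here, so nothing within the data shows how this exchange of one halogen for another moves the read-out. Compound 3 is therefore expected to stay close to compound 2, with the step from compound 2 to compound 3 estimated at a 1.2-fold lower number from compound 2 to compound 3 (0.07 log units; within the scatter), not beyond the usual scatter in either direction. On this basis compound 3 is expected to give about 7000 nM, within a range from 3500 nM to 16000 nM.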

Compound 3, half-maximal inhibitory concentration: 6750 nM
The estimate for compound 3 lay 1.0-fold (0.02 log units) above the measured number; measured number inside the range.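

With this result the data hold their first step at this position: bromo in place of chloro, on the aromatic carbon ortho to a hydroxy group, gives a 1.2-fold lower number from compound 2 to compound 3 (0.08 log units; within the scatter) in this assay. Compound 2 and compound 3 therefore cannot be told apart in this read-out, and across these two halogens the position shows no sensitivity to the exchange. Nothing measured here bears on why the two halogens read alike.

The nitro group of compound 1 cannot be compared with either halogen, since compound 1 stands at "not determined" (no result reported). The compounds shown leave open whether an amine, a methoxy group or a plain hydrogen on this carbon would read differently from chloro and bromo, and whether an amide in place of the ester would shift the read-out.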